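Swapping Ethoxycarbonyl for Benzyloxycarbonyl on Compound 2

The source may hold more compounds than are shown below. What is called first, only, known or untested is meant among the compounds shown, and "the series" means these compounds.

For the measured compounds named here, in a functional assay on HeLa cells (Homo sapiens) for antiproliferative activity, read by MTT assay, with a stated time of 48 h (on this read-out lower numbers stand for stronger inhibition of growth and higher numbers for weaker inhibition of growth), compound 2 `CCOC(=O)N1N=C(c2ccc(OC)cc2)CC1c1cc(OC)c(OC)c(OC)c1` gives 8710 nM as the only true number so far.

Compound 1 `COc1cccc(C2=NN(C(=O)OCc3ccccc3)C(c3cc(OC)c(OC)c(OC)c3)C2)c1` gives > 10000 nM as a limit and not a number.

Compound 3 `COc1ccc(C2=NN(C(=O)OCc3ccccc3)C(c3cc(OC)c(OC)c(OC)c3)C2)cc1` keeps the core of compound 2 but has phenyl in place of methyl on a saturated chain carbon bound to an oxygen next to a carbonyl group. Going by the values given here, no measured pair shows this change, so no direction can be read from the data. A small step of a 1.0-fold higher number from compound 2 to compound 3 (0.01 log units; within the scatter) is expected, within the usual scatter. Compound 3 is estimated at 9000 nM with an expected range from 3000 nM to 30000 nM in this estimate.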

Compound 3, concentration for 50% growth inhibition: > 10000 nM
Compound 3 ended at the assay's limit (the forecaster's own chance of this, stated with the estimate: 50%); middle value at least 1.1-fold (0.04 log units) from the limit.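

In this assay, phenyl in place of methyl, which turns ethoxycarbonyl into benzyloxycarbonyl, gives an at least 1.1-fold higher number from compound 2 to compound 3 (0.05 log units; that floor lies within the scatter). So the larger group brings no sign of stronger growth inhibition, but the value of compound 3 is a limit and not a number, which hides the true size of this step, and the step between compound 1 and compound 3 cannot be read. Little of the scale can be read here: the limit of > 10000 nM in this assay, at which 2 of the 3 values shown sit.

On these data alone, whether an amine or a longer chain on that saturated chain carbon would lower the number stays open.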